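Shortening a thiophene side chain: expected cytotoxicity of compound 4

The compounds below may be only part of what the source reports. "The series", "measured", "known", "first", "only" and "open" are said of these compounds alone.

Measured compounds:
compound 1, `CCCCc1csc(CN[C@@H]2C[C@H]3C[C@@H]([C@H]2C)C3(C)C)c1`: 12500 nM
compound 2, `C[C@H]1[C@H](NCc2cncs2)C[C@H]2C[C@@H]1C2(C)C`: > 100000 nM
compound 3, `Cc1ccc(CN[C@@H]2C[C@H]3C[C@@H]([C@H]2C)C3(C)C)s1`: 780 nM

In an ADME assay on MDCK cells (Canis lupus familiaris) for cytotoxicity, read by microscopy, with a stated time of 48 h (on this read-out lower numbers stand for higher toxicity in this test and higher numbers for lower toxicity in this test), compound 1 gives 12500 nM, the highest of the two numbers shown. The nearest number is that of compound 3, which gives 780 nM in this assay. Compound 2 gives > 100000 nM in this assay, which is a limit of the assay and not a number (the limit of > 100000 nM in this assay, at which 1 of the 3 values shown sits). Among the compounds with values here, the only step between measured compounds is an at least 120-fold lower number from compound 2 to compound 3 (2.10 log units; beyond the scatter), a change of the aromatic ring rather than of a chain.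

Compound 4, `CCc1csc(CN[C@@H]2C[C@H]3C[C@@H]([C@H]2C)C3(C)C)c1`, differs from compound 1 by hydrogen in place of ethyl on a saturated chain carbon, two bonds along the chain from an aromatic carbon; read one bond further out, this is butyl to ethyl. Within the data shown here, no measured step concerns such a shortening of a chain, and the ring change between compound 2 and compound 3 does not bear on it. Compound 1 and compound 3 differ in more than one place, so their gap cannot be assigned to chain length alone. Compound 4 is therefore expected to stay close to compound 1, with a step of a 1.3-fold lower number from compound 1 to compound 4 (0.10 log units; within the scatter) in this assay that is not expected to exceed the scatter. The estimate for compound 4 in this assay is 10000 nM, with a range from 3000 nM to 40000 nM.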

Compound 4, minimum cytotoxic concentration: 25000 nM
For compound 4 the middle estimate is 2.5-fold (0.40 log units) below the measured one, within the range that was stated.
By their numbers in this assay, from the lowest: compound 3; then compounds 1 and 4 (each within the scatter of the next). At a limit, above all of these: compound 2.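

In this assay the change from butyl to ethyl gives a 2.0-fold higher number from compound 1 to compound 4 (0.30 log units; within the scatter) and is the only step shown that concerns the length of this chain. On a saturated chain carbon, two bonds along the chain from an aromatic carbon, hydrogen in place of ethyl therefore leaves the read-out where it was within the usual scatter, and compound 1 and compound 4 cannot be ranked against each other. The earlier compounds offered no pair that isolated chain length, and nothing shown here bears on why the read-out holds at this place.

The compounds shown leave open whether a longer chain such as hexyl, or a chain ending in an amine or a carboxylic acid, would stay as close to compound 1 as the ethyl chain of compound 4 does. From the compounds shown here alone, it also remains open whether a methyl at this same place would hold the read-out, and compound 3 cannot settle that, as it differs from compound 1 and compound 4 in more than one place.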